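Ethoxycarbonyl Extension on the Sulfanyl Methyl of Compound 2

The source may hold more compounds than are shown below. What is called first, only, known or untested is meant among the compounds shown, and "the series" means these compounds.

Compound 2 `COc1ccc(-n2c(SC)nnc2-c2cc(OC)c(OC)c(OC)c2)cc1` is one of three measured analogues sharing a core and differing only at a sulfur. In a functional assay on PC-3 cells (Homo sapiens) for inhibition, read by MTT assay, with a stated time of 48 h (on this read-out lower numbers stand for stronger inhibition and higher numbers for weaker inhibition), compound 2 gives > 60000 nM, which is a limit of the assay and not a number. Compound 1 `COc1ccc(-n2c(S)nnc2-c2cc(OC)c(OC)c(OC)c2)cc1` gives > 60000 nM in this assay, likewise a limit. Compound 3 `COc1ccc(-n2c(SCC(=O)c3ccc4ccccc4c3)nnc2-c2cc(OC)c(OC)c(OC)c2)cc1` gives > 60000 nM in this assay, again a limit. The steps a step that the two limits leave unreadable from compound 1 to compound 2 and a step that the two limits leave unreadable from compound 2 to compound 3 are therefore unreadable, due to the limit of > 60000 nM in this assay, at which 3 of the 3 values shown sit. The unmeasured compound 4 `CCOC(=O)CSc1nnc(-c2cc(OC)c(OC)c(OC)c2)n1-c1ccc(OC)cc1` differs from compound 2 by ethoxycarbonyl in place of hydrogen on a saturated chain carbon bound to a sulfur. Both neighbouring steps bear on this change yet give no readable size, so no step beyond the scatter is expected in this assay. Compound 4 is expected to remain at the limit, estimated at 60000 nM, between 20000 nM and 200000 nM. This estimate corresponds to an expected step of a number no higher from compound 2 to compound 4 (the limit leaves the size open).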

Compound 4, half-maximal inhibitory concentration: > 60000 nM
Compound 4: a limit, no number; the forecaster's own chance of this, stated with the estimate: 85%; the middle value lies on the limit itself.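

Compound 4 adds no readable step against compound 1, compound 2 or compound 3, because each value is a limit and not a number: the limit of > 60000 nM in this assay, at which 4 of the 4 values shown sit.

The compounds shown leave open whether any change at the sulfur gives a readable value in this assay.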